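The source may hold more compounds than are shown below. What is called first, only, known or untested is meant among the compounds shown, and "the series" means these compounds.

Compound 1 `CN(C(=O)c1ccc(Cl)cc1)c1ccc2[nH]c(-c3n[nH]c4ccccc34)cc2n1` is the reference point of this small set. In a functional assay on SMMC-7721 cells (Homo sapiens) for antiproliferative activity, read by MTT assay, with a stated time of 72 h (a lower number here means a stronger inhibitor, a higher number a weaker inhibitor), compound 1 gives 2420 nM, the lowest number among the three compounds measured. Compound 2 `CN(C(=O)c1ccc([N+](=O)[O-])cc1)c1ccc2[nH]c(-c3n[nH]c4ccccc34)cc2n1` gives 18400 nM in this assay, and compound 3 `CN(C(=O)c1ccccc1)c1ccc2[nH]c(-c3n[nH]c4cc(Cl)ccc34)cc2n1` gives 11300 nM; both numbers stand above that of compound 1 by more than the scatter, so compound 1 is the strongest inhibitor of the three on the numbers shown.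

Compound 4 `CN(c1ccc2[nH]c(-c3n[nH]c4ccccc34)cc2n1)S(=O)(=O)c1ccc(Br)cc1` differs from compound 1 in one place: (4-bromophenyl)sulfonyl in place of (4-chlorophenyl)carbonyl on a nitrogen on an aromatic ring. Among the compounds with values here, no measured step changes this part of the molecule in the same way. Within the data shown here, the only measured single step, a 7.6-fold higher number from compound 1 to compound 2 (0.88 log units; beyond the scatter), shows that exchanging the group on the aromatic ring of the amide substituent can move the number beyond the scatter, in the direction of a weaker inhibitor. Compound 3 differs from compound 1 in two places and offers no direct comparison. The step to compound 4 replaces the whole attachment on that nitrogen, not merely the group on its ring, so the outcome is uncertain, but a shift toward a higher number of about the size seen for compound 2 seems the more likely reading. Compound 4 is therefore expected to give 6000 nM in this assay, within 1500 nM to 20000 nM, a step of a 2.5-fold higher number from compound 1 to compound 4 (0.39 log units; beyond the scatter).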

Compound 4, half-maximal inhibitory concentration: 11500 nM
The estimate for compound 4 lay 1.9-fold (0.28 log units) below the measured number, and the stated range covers the measured number.
By their numbers in this assay, from the lowest: compound 1; then compounds 3, 4 and 2 (each within the scatter of the next).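

In this assay, the step shows that the whole attachment on the nitrogen can be exchanged with an effect beyond the scatter, not only the group on its aromatic ring: a 4.8-fold higher number from compound 1 to compound 4 (0.68 log units; beyond the scatter) when (4-bromophenyl)sulfonyl takes the place of (4-chlorophenyl)carbonyl. Like a 7.6-fold higher number from compound 1 to compound 2 (0.88 log units; beyond the scatter), this change goes toward a higher number, so both single changes measured from compound 1 at this attachment give a weaker inhibitor, although the change to compound 4 exchanges carbonyl for sulfonyl and chlorine for bromine together, and the step cannot divide its size between the two. Nothing measured here gives a reason for the step.

The compounds shown leave open whether the sulfonyl or the bromine carries the step, a question that (4-chlorophenyl)sulfonyl on the same nitrogen would address directly. They also leave open how the number would respond to a methoxy group or an amine on that aromatic ring, or to a longer chain in place of the ring, with the core of compound 1 kept unchanged.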